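Pyridine for Pyrazine at the Core of Compound 3

The source may report more compounds than this note shows. Statements on the series, on what has been measured and on what is new or still open speak of the compounds shown alone.

Measured compounds:
compound 1, `c1cc(Nc2nccc(-c3ccco3)n2)cc(-n2ccnc2)c1`, 800 nM
compound 2, `CC1CCN(c2ccc(Nc3nccc(-c4cccs4)n3)cc2)CC1`, 400 nM
compound 3, `CCc1ccc(Nc2nccc(-c3cnccn3)n2)cc1`, 1900 nM

Of the compounds shown here, three sharing one core have been tested in a functional assay for inhibition, with Homo sapiens as the target; a lower number here means a stronger inhibitor, a higher number a weaker inhibitor. Compound 2 gives 400 nM, and compound 1 gives 800 nM. Compound 3 gives the highest number of the three, 1900 nM; its gap to compound 1 and its wider gap to compound 2 both lie beyond the scatter, so compound 3 is the weakest inhibitor shown.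

Compound 4, `CCc1ccc(Nc2nccc(-c3ccccn3)n2)cc1`, has not been measured. It differs from compound 3 in a single spot: pyridin-2-yl in place of pyrazin-2-yl on an aromatic carbon. Among the compounds with values here, no measured pair shows this kind of change, so the size of the step is not known from the data. Since compound 1 and compound 2, which carry other five-membered aromatic rings at that same carbon, give lower numbers than compound 3, a modest downward step is expected, possibly no larger than the scatter. The step from compound 3 to compound 4 is estimated as a 1.9-fold lower number from compound 3 to compound 4 (0.28 log units; within the scatter). Compound 4 is expected to give about 1000 nM, within a range from 400 nM to 2500 nM.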

Compound 4, half-maximal inhibitory concentration: 2100 nM
Compound 4: the middle estimate sits 2.1-fold (0.32 log units) below what was measured; the range from low to high includes it.
By their numbers in this assay, from the lowest: compounds 2 and 1 (each within the scatter of the next); then compounds 3 and 4 (each within the scatter of the next).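

In this assay, putting pyridin-2-yl in place of pyrazin-2-yl on this aromatic carbon gives a 1.1-fold higher number from compound 3 to compound 4 (0.04 log units; within the scatter), the first step measured at this position. Taking one ring nitrogen, and with it one hydrogen-bond acceptor, out of the group at this carbon therefore leaves the number unchanged within the scatter, and the two six-membered aromatic rings cannot be told apart in this assay. Nothing available explains why this change has so little effect.

Compound 1 and compound 2 differ from compound 3 and compound 4 in more than one place, so whether their five-membered aromatic rings account for their lower numbers cannot be read. As far as these compounds go, it also remains open how the number would respond to an amine or a carboxylic acid on the pyridin-2-yl ring.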